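Quinazoline thioacetamides: nitro to chloro-fluoro swap

This account rests on a few compounds, and the source may have more. Where it says the series, first, only, none or still open, it means among the compounds named here.

Measured so far:
compound 1 `O=C(CSc1nc(Nc2ccccc2)c2ccccc2n1)Nc1ccccc1Cl` — 24800 nM
compound 2 `C=CC(=O)Nc1cccc(NC(=O)CSc2nc(Nc3cccc([N+](=O)[O-])c3)c3ccccc3n2)c1` — > 50000 nM

In a functional assay on MGC-803 cells (Homo sapiens) for inhibition, read by MTT assay, with a stated time of 72 h (on this read-out higher numbers stand for weaker inhibition and lower numbers for stronger inhibition), compound 1 gives 24800 nM. For compound 2 this assay reports only a limit, > 50000 nM, so compound 2 sits at the weak end of the two values shown (the limit of > 50000 nM in this assay, at which 1 of the 2 values shown sits). Compound 3 `C=CC(=O)Nc1cccc(NC(=O)CSc2nc(Nc3ccc(F)c(Cl)c3)c3ccccc3n2)c1` differs from compound 2 by 3-chloro-4-fluorophenyl in place of 3-nitrophenyl on a nitrogen on an aromatic ring. Within the data shown here, no step between measured compounds is available to size this change; compound 3 is expected to stay near the limit, with a step from compound 2 of an at least 1.1-fold lower number from compound 2 to compound 3 (0.04 log units; that floor lies within the scatter) that need not exceed the scatter. The estimate for compound 3 in this assay is 45000 nM, within 15000 nM to 120000 nM.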

Compound 3, half-maximal inhibitory concentration: 7850 nM
Beside the measured number, compound 3's estimate is 5.7-fold (0.76 log units) above it; the measured number lies below the stated range.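

In this assay, the group on a nitrogen on an aromatic ring governs the read-out: 3-chloro-4-fluorophenyl in place of 3-nitrophenyl gives an at least 6.3-fold lower number from compound 2 to compound 3 (0.80 log units; beyond the scatter). This is the only step shown in the series, and it shows that this position is not silent. Its true size stays unknown because compound 2 is reported only as a limit: the limit of > 50000 nM in this assay, at which 1 of the 3 values shown sits.

From the compounds shown here alone, it remains open whether the chlorine or the fluorine alone would carry the step. An amine or a methoxy group on that phenyl ring is also untested among the compounds shown here.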